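Notes on an acetoxy replacement in a small series

The compounds below may be only part of what the source reports. "The series", "measured", "known", "first", "only" and "open" are said of these compounds alone.

Going by the values given here, in a functional assay on Bel-7402 cells (Homo sapiens) for cytotoxicity, read by MTT assay, with a stated time of 72 h (on this read-out higher numbers stand for weaker inhibition and lower numbers for stronger inhibition), compound 1 `O=C1C=CCC/C1=C\C=C\c1ccc(F)cc1` gives 1800 nM and compound 2 `COc1ccccc1/C=C/C=C1\CCC=CC1=O` gives 2600 nM within the scatter of each other, so compound 1 stands level with its only measured neighbour. The change to compound 3 `CC(=O)Oc1ccc(/C=C/C=C2\CCC=CC2=O)cc1` is acetoxy in place of fluoro on an aromatic carbon, para to a large group, with acetoxy in place of fluoro on an aromatic carbon as the count. Among the compounds with values here, no measured step covers this change, so in this assay a shift no larger than the scatter is expected, with no firm direction. The expected step of a 1.2-fold higher number from compound 1 to compound 3 (0.09 log units; within the scatter) is an estimate only. For compound 3 2200 nM is expected, with 800 nM to 6000 nM as the estimated range.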

Compound 3, half-maximal inhibitory concentration: 3800 nM
For compound 3 the middle estimate is 1.7-fold (0.24 log units) below the measured one; measured number inside the range.
By their numbers in this assay, from the lowest: compounds 1, 2 and 3 (each within the scatter of the next, the first and the last beyond it).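

Acetoxy in place of fluoro on an aromatic carbon, para to a large group, gives a 2.1-fold higher number from compound 1 to compound 3 (0.32 log units; beyond the scatter) in this assay, the first measured step at this position. The step is modest and points towards weaker inhibition, so the position carries the larger acetoxy group with inhibition weakened but not lost. No evidence on the cause of this step is at hand.

As far as these compounds go, whether a hydroxyl group, an amine or a carboxylic acid at this position would stay level with compound 1 remains open. So does whether the same replacement would give a step of similar size on another compound of the series.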